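This account rests on a few compounds, and the source may have more. Where it says the series, first, only, none or still open, it means among the compounds named here.

Working notes on the series

Three compounds of this set have been run in an ADME assay on Vero cells (Chlorocebus sabaeus) for inhibition (a higher number here means that more compound is tolerated, a lower number that less compound is tolerated), and a fourth awaits measurement there.

Compound 1 `COc1ccc(/C=C2\CCC/C(=C\c3ccc([N+](=O)[O-])cc3)C2=O)cc1` and compound 2 `COc1ccc(/C=C2\CCC/C(=C\c3ccc(F)cc3)C2=O)cc1` share one core and differ only at the aromatic carbon, where the difference is nitro in place of fluoro on an aromatic carbon. In this assay compound 2 gives 378000 nM. Compound 1 gives 435000 nM. The step is a 1.2-fold higher number from compound 2 to compound 1 (0.06 log units; within the scatter), so the two numbers are not to be told apart.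

Compound 3 `COc1cccc(/C=C2\CCC/C(=C\c3ccc(F)cc3)C2=O)c1OC` carries a second core; the difference between the two cores is not broken down here. In this assay compound 3 gives 33200 nM, the lowest of the three numbers, and its gaps to compound 2 and to compound 1 both lie beyond the scatter.

Compound 4 `COc1cccc(/C=C2\CCC/C(=C\c3ccc([N+](=O)[O-])cc3)C2=O)c1OC` stands to compound 3 as compound 1 stands to compound 2. Among the compounds with values here, the change is nitro in place of fluoro on an aromatic carbon; its place matches the one seen between compound 2 and compound 1 word for word, so it is taken as the same change, made on the second core.

Within the data shown here, the only measured instance of nitro in place of fluoro on an aromatic carbon moved the number by a 1.2-fold higher number from compound 2 to compound 1 (0.06 log units; within the scatter), which is no change to speak of. On that basis the expected step from compound 3 to compound 4 is a 1.1-fold higher number from compound 3 to compound 4 (0.04 log units; within the scatter). Compound 4 is therefore estimated at 36000 nM, with the expectation spanning 15000 nM to 85000 nM. Going by these compounds, the core difference between compound 2 and compound 3 is a single case, so whether the change carries over to the second core is untested, and the range is set wide accordingly.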

Compound 4, half-maximal cytotoxic concentration: < 10000 nM
Compound 4 gave a limit, no number; the forecaster's own chance of this, stated with the estimate: 5%; middle value at least 3.6-fold (0.55 log units) from the limit.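

In this assay compound 4 gives < 10000 nM, which is a limit of the assay and not a number: the limit of < 10000 nM in this assay, at which 1 of the 4 values shown sits.

Even with that limit, 4-fluorophenyl to 4-nitrophenyl does not read the same on the two cores, with a 1.2-fold higher number from compound 2 to compound 1 (0.06 log units; within the scatter) on the core of compound 1 and an at least 3.3-fold lower number from compound 3 to compound 4 (0.52 log units; beyond the scatter) on the core of compound 3, and the two steps differ: the same change on two cores in this assay, a 1.2-fold higher number (0.06 log units; within the scatter) from compound 2 to compound 1 and an at least 3.3-fold lower number (0.52 log units; beyond the scatter) from compound 3 to compound 4, at least 3.8-fold (0.58 log units) apart, beyond the scatter of two such steps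

In this series, then, the result of this change on the core of compound 1 does not carry over to the core of compound 3, but the data do not show how large the step on the core of compound 3 really is, why the two cores part, or whether the same would hold on any further core, since each core contributes a single pair.

Which part of the difference between the two cores goes with this split stays open. Going by these compounds, it is also open whether another group on the same aromatic carbon, such as an amine or a carboxylic acid, would likewise read differently on the two cores in this assay.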